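The source may report more compounds than this note shows. Statements on the series, on what has been measured and on what is new or still open speak of the compounds shown alone.

Compound 1 `CCCc1nc(C)c2c(C)nn(CC(O)CO)c(=O)n12` is one of three measured analogues sharing a core. In a functional assay for inhibition, with Homo sapiens as the target (on this read-out lower numbers stand for stronger inhibition and higher numbers for weaker inhibition), compound 1 gives > 48000 nM, which is a limit of the assay rather than a number. Compound 2 `CCCc1nc(C)c2cnn(CC(O)CO)c(=O)n12` in this assay gives > 48000 nM, again a limit. Compound 3 `Cc1nc(C)n2c(S)nncc12` in this assay gives > 48000 nM, also a limit. Among the compounds with values here, the only step between measured neighbours, a step that the two limits leave unreadable from compound 1 to compound 2, is left unreadable by the two limits, and the whole picture is summed up by the limit of > 48000 nM in this assay, at which 3 of the 3 values shown sit.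

Compound 4 `CCCc1nc(C)c2c(C)nn(CC)c(=O)n12` differs from compound 1 by methyl in place of 1,2-dihydroxyethyl on a saturated chain carbon bound to an aromatic nitrogen. Within the data shown here, no measured step bears on that change: the one measured step is unreadable, and all three values are limits. Since compound 1 and its two companions all rest at the limit, compound 4 is expected to behave alike, with a step of a number no higher from compound 1 to compound 4 (the limit leaves the size open) that is expected to mean nothing beyond the scatter. Compound 4 is therefore estimated at 48000 nM in this assay, within a range of 15000 nM to 150000 nM, and most probably reported only as a limit.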

Compound 4, half-maximal inhibitory concentration: > 48000 nM
Compound 4: only a limit was reported (the forecaster's own chance of this, stated with the estimate: 85%); the middle value lies on the limit itself.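

No step can be read from compound 1 to compound 4, since both values are limits, and the series comes down to a single figure: the limit of > 48000 nM in this assay, at which 4 of the 4 values shown sit. The compounds shown leave open which change to the shared core, if any, would give a measurable inhibition.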